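Phenyl in Place of 2-Fluoroethyl on the Cyclobutyl Side Chain

The source may report more compounds than this note shows. Statements on the series, on what has been measured and on what is new or still open speak of the compounds shown alone.

Compound 1 `CCCCC1([C@H](O)/C=C/[C@H]2COC(=O)N2CCSc2nc(C(=O)O)cs2)CCC1` is the reference point: in an assay on isolated protein for agonist activity at prostaglandin E2 receptor EP2 subtype (Homo sapiens) (a higher number here means that more compound is needed for the effect, a lower number that less compound is needed), compound 1 gives 2.9 nM. Compound 2 `O=C(O)c1csc(SCCN2C(=O)OC[C@@H]2/C=C/[C@@H](O)C2(CCCCF)CCC2)n1` carries fluoro in place of hydrogen on a saturated chain carbon, four bonds along the chain from a saturated ring carbon, and in this assay compound 2 gives 2.9 nM, so the step of no change at the digits printed from compound 1 to compound 2 (within the scatter) shows that this terminal change left the read-out where it was. For the measured compounds named here, compound 2 thus stands level with compound 1 on the numbers in hand, and no other measured compound sits beside it.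

Compound 3 `O=C(O)c1csc(SCCN2C(=O)OC[C@@H]2/C=C/[C@@H](O)C2(CCc3ccccc3)CCC2)n1` differs from compound 2 by phenyl in place of 2-fluoroethyl on a saturated chain carbon, two bonds along the chain from a saturated ring carbon. Going by the values given here, the only measured step, from compound 1 to compound 2, concerned a small change at the far end of the same chain and was flat within the scatter; it bears on the present step only as a hint that the end of this chain tolerates variation, while the present change is larger. On that basis compound 3 is expected to stay near compound 2, with the step from compound 2 to compound 3 estimated as a 1.6-fold higher number from compound 2 to compound 3 (0.19 log units; within the scatter), either flat or a modest loss. The estimate for compound 3 in this assay is 4.5 nM, within a range from 1.5 nM to 15 nM.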

Compound 3, half-maximal effective concentration: 160 nM
Estimate against measurement, compound 3: 36-fold (1.55 log units) below, outside the stated range (above it).
By their numbers in this assay, from the lowest: compounds 1 and 2 (each within the scatter of the next); then compound 3.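

At the place on a saturated chain carbon, two bonds along the chain from a saturated ring carbon, this assay does not accept every end group: phenyl in place of 2-fluoroethyl brings a 55-fold higher number from compound 2 to compound 3 (1.74 log units; beyond the scatter), and phenyl in place of ethyl brings a 55-fold higher number from compound 1 to compound 3 (1.74 log units; beyond the scatter). The same chain had shown no change at the digits printed from compound 1 to compound 2 (within the scatter) when fluoro replaced hydrogen at its far end, so that flat step does not carry over to a change from a short open chain to phenyl, which enters as one six-membered aromatic ring of carbon only. Nothing on hand explains why the number rises this far.

The compounds shown leave open whether the loss follows the aromatic ring itself or simply a larger end group, a question that cyclohexyl or a longer unbranched chain such as hexyl at the same place would help to separate. They also leave open whether any of the lost read-out would return with benzyl, which holds the ring on a shorter chain, or with pyridyl in place of phenyl.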